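This account rests on a few compounds, and the source may have more. Where it says the series, first, only, none or still open, it means among the compounds named here.

Of the compounds shown here, three sharing one core have been tested in a functional assay on HEK293 cells (Homo sapiens) for cytotoxicity; on this read-out lower numbers stand for higher toxicity in this test and higher numbers for lower toxicity in this test. Compound 1 `COc1ccc([C@H]2CC(=O)N(c3ccccc3)C2)cc1OC1CCCC1` gives > 10000 nM, which is a limit. Compound 2 `COc1ccc([C@H]2CC(=O)N(c3cccc(S(C)(=O)=O)c3)C2)cc1OC1CCCC1` gives > 10000 nM, also a limit. Compound 3 `COc1ccc(S(=O)(=O)Nc2cccc(N3C[C@@H](c4ccc(OC)c(OC5CCCC5)c4)CC3=O)c2)cc1` gives > 10000 nM, again a limit, so it has no exact number in this assay. The whole picture so far is the limit of > 10000 nM in this assay, at which 3 of the 3 values shown sit.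

Compound 4 `COc1ccc([C@H]2CC(=O)N(c3cccc(NS(=O)(=O)c4cccc(OC(F)(F)F)c4)c3)C2)cc1OC1CCCC1` carries a single change from compound 3: 3-(trifluoromethoxy)phenyl in place of 4-methoxyphenyl on a sulfonyl sulfur. That is, 3-(trifluoromethoxy)phenyl stands in place of 4-methoxyphenyl on a sulfonyl sulfur. Among the measured compounds shown here, no measured step changes the group at this place. The nearest evidence comes from changes on an aromatic carbon, and these show a step that the two limits leave unreadable from compound 1 to compound 2, a step that the two limits leave unreadable from compound 1 to compound 3 and a step that the two limits leave unreadable from compound 2 to compound 3. None of them therefore offers a size or direction to carry over.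

The expectation rests on compound 3 at > 10000 nM, a limit. The expected step, with no direction beyond the scatter, is a step that the limit leaves unreadable from compound 3 to compound 4. For compound 4 the estimated value is 15000 nM, with an expected range of 6000 nM to 40000 nM.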

Compound 4, half-maximal cytotoxic concentration: > 10000 nM
Compound 4 gave a limit, no number; the forecaster's own chance of this, stated with the estimate: 80%; the middle value does not contradict the limit.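

Compound 4 gives > 10000 nM in this assay, which is a limit. Among the compounds shown here, compound 3 also stands at a limit, so no step between compound 3 and compound 4 can be read. The compounds shown leave open at what concentration, if any, any of them becomes cytotoxic: the limit of > 10000 nM in this assay, at which 4 of the 4 values shown sit.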